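The source may report more compounds than this note shows. Statements on the series, on what has been measured and on what is new or still open speak of the compounds shown alone.

Measured so far:
compound 1, `CC(C)(C)[C@H](N)CN(C(=O)[C@@H]1C[C@H]1c1ccccc1)c1ccc(-c2ccccc2)cc1`: 11 nM
compound 2, `CC(C)C[C@H](N)CCN(C(=O)[C@@H]1C[C@H]1c1ccccc1)c1ccc(-c2ccccc2)cc1`: 3 nM
compound 3, `CC[C@H](C)[C@H](N)CN(C(=O)[C@@H]1C[C@H]1c1ccc(C#N)cc1)c1ccc(-c2ccccc2)cc1`: > 25000 nM

In a functional assay for agonist activity at G protein-coupled receptor 88 (Homo sapiens), read by HTRF and cAMP accumulation (a higher number here means that more compound is needed for the effect, a lower number that less compound is needed), compound 3 gives > 25000 nM, which is a limit of the assay and not a number (the limit of > 25000 nM in this assay, at which 1 of the 3 values shown sits). The compound still to be measured is compound 4 `CC[C@H](C)[C@H](N)CN(C(=O)[C@@H]1C[C@H]1c1cccs1)c1ccc(-c2ccccc2)cc1`. It differs from compound 3 in one place: thiophen-2-yl in place of 4-cyanophenyl on a saturated ring carbon. Among the compounds with values here, the single measured step, a 3.7-fold lower number from compound 1 to compound 2 (0.56 log units; beyond the scatter), changes the amine-bearing chain and leaves the group on the saturated ring carbon untouched, so no measured step bears directly on the change from compound 3 to compound 4. Compound 1 carries a plain phenyl on that saturated ring carbon and gives 11 nM; compound 2 carries the same phenyl and gives 3 nM. Compound 4 is therefore expected to return to a measurable number in this assay, estimated at 60 nM, most likely between 5 nM and 3000 nM. The expected step for compound 4 is an at least 410-fold lower number from compound 3 to compound 4 (2.61 log units; beyond the scatter), with wide uncertainty.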

Compound 4, half-maximal effective concentration: 360 nM
The estimate for compound 4 lay 6.0-fold (0.78 log units) below the measured number, and the stated range covers the measured number.
By their numbers in this assay, from the lowest: compound 2; then compound 1; then compound 4. At a limit, above all of these: compound 3.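

Compound 3 stands at a limit of this assay, not at a number: the limit of > 25000 nM in this assay, at which 1 of the 4 values shown sits. With the rest of the structure unchanged, replacing 4-cyanophenyl with thiophen-2-yl on the saturated ring carbon gives an at least 69-fold lower number from compound 3 to compound 4 (1.84 log units; beyond the scatter), so the true step could be larger still. The earlier step changed only the amine-bearing chain, whereas this pair shows that the group on the saturated ring carbon can by itself decide whether a measurable number appears at all.

On these data alone, what remains open is whether the nitrile or the six-membered ring of 4-cyanophenyl matters here, a question that a plain phenyl on the amine chain of compound 3 and compound 4 would address. As far as these compounds go, how groups such as thiophen-3-yl or 4-methoxyphenyl would behave at this position also remains open.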